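This account rests on a few compounds, and the source may have more. Where it says the series, first, only, none or still open, it means among the compounds named here.

Measured compounds:
compound 1 `C=C/C=C\[C@H](C)[C@H](OC(N)=O)[C@@H](C)[C@H](O)[C@@H](C)C/C(C)=C\[C@H](C)[C@@H](O)[C@@H](C)/C=C\CCc1cccc(Cl)c1`: 580 nM
compound 2 `C=C/C=C\[C@H](C)[C@H](OC(N)=O)[C@@H](C)[C@H](O)[C@@H](C)C/C(C)=C\[C@H](C)[C@@H](O)[C@@H](C)/C=C\CCc1ccc(Oc2ccccc2)cc1`: 10000 nM
compound 3 `C=C/C=C\[C@H](C)[C@H](OC(N)=O)[C@@H](C)[C@H](O)[C@@H](C)C/C(C)=C\[C@H](C)[C@@H](O)[C@@H](C)/C=C\CCc1cccc(O)c1C`: 910 nM

In a functional assay on A549 cells (Homo sapiens) for cytotoxicity (on this read-out higher numbers stand for weaker inhibition and lower numbers for stronger inhibition), compound 1 gives the lowest of the three numbers. Its nearest neighbour is compound 3, reached by a 1.6-fold higher number from compound 1 to compound 3 (0.20 log units; within the scatter), so these two cannot be told apart. Compound 2 lies far off; the two values show a gap beyond the scatter.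

Compound 4 `C=C/C=C\[C@H](C)[C@H](OC(N)=O)[C@@H](C)[C@H](O)[C@@H](C)C/C(C)=C\[C@H](C)[C@@H](O)[C@@H](C)/C=C\CCc1cccc(F)c1` differs from compound 1 by fluoro in place of chloro on an aromatic carbon. Among the measured compounds shown here, no measured step touches this exact exchange; the one step that changes the same ring, a 1.6-fold higher number from compound 1 to compound 3 (0.20 log units; within the scatter), stayed within the scatter, and the only large step, to compound 2, involves a quite different group. An exchange of one small halogen for another on the same ring carbon is therefore expected to move the number little, if at all.

For compound 4 the estimate is 800 nM, with a range from 300 nM to 2500 nM, which would mean a 1.4-fold higher number from compound 1 to compound 4 (0.14 log units; within the scatter).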

Compound 4, half-maximal inhibitory concentration: 650 nM
For compound 4 the middle estimate is 1.2-fold (0.09 log units) above the measured one, within the range that was stated.
By their numbers in this assay, from the lowest: compounds 1, 4 and 3 (each within the scatter of the next); then compound 2.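

In this assay the exchange of chloro for fluoro on this aromatic carbon gives a 1.1-fold higher number from compound 1 to compound 4 (0.05 log units; within the scatter) and so cannot be told from no change at all. The other step, a 1.4-fold lower number from compound 3 to compound 4 (0.15 log units; within the scatter), also stays within the scatter, so the 3-fluorophenyl, 3-chlorophenyl and 3-hydroxy-2-methylphenyl compounds cannot be separated on this read-out. Nothing available explains this result. Still open, as far as these compounds go, is whether an amine or a carboxylic acid on the same aromatic carbon would leave the number just as unmoved.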